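Piperazine nitrogen substituent and stability in human liver microsomes

The source may report more compounds than this note shows. Statements on the series, on what has been measured and on what is new or still open speak of the compounds shown alone.

Working notes on the series. Three compounds have numbers in an ADME assay on microsomes from liver (Homo sapiens) for metabolic stability, read by LC-MS, with a stated time of 10 min, tested at 0.5 uM; on this read-out lower numbers stand for a less stable compound and higher numbers for a more stable compound. Compound 1 `c1cnc2c(c1)CCC[C@@H]2N(CCCN1CCNCC1)Cc1nc2ccccc2s1` gives 50%. Compound 2 `CCN1CCN(CCCN(C[C@H]2Cc3ccccc3CN2)[C@H]2CCCc3cccnc32)CC1` gives 59%. Compound 3 `CN1CCN(CCCN(C[C@H]2Cc3ccccc3CN2C)[C@H]2CCCc3cccnc32)CC1` gives 60%. Compound 2 differs from compound 3 and from compound 1 by less than the usual scatter, so the three measured compounds cannot be told apart on this read-out. Compound 4 `c1ccc2c(c1)CN[C@@H](CN(CCCN1CCN(C3CC3)CC1)[C@H]1CCCc3cccnc31)C2` has not yet been measured; it differs from compound 2 in one place: cyclopropyl in place of ethyl on an amine nitrogen in a ring. Going by the values given here, no pair of measured compounds isolates this change, so nothing in the data points to a step beyond the scatter in this assay in either direction. The expected step is a number 3 percentage points higher from compound 2 to compound 4 (within the scatter). Compound 4 is expected to give 62% in this assay, within a range from 45% to 80%.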

Compound 4, percent of the compound remaining: 21%
Compound 4: the middle estimate sits 41 percentage points above what was measured, and the stated range ends above it.
By their numbers in this assay, from the lowest: compound 4; then compounds 1, 2 and 3 (each within the scatter of the next).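

In this assay, going by these compounds alone, cyclopropyl in place of ethyl on an amine nitrogen in a ring gives a number 38 percentage points lower from compound 2 to compound 4 (beyond the scatter), the only step so far that lies beyond the scatter. Stability at this position therefore depends strongly on the substituent, and swapping an open ethyl for a small carbon ring is enough to show it. Nothing at hand accounts for the size of this step. As far as these compounds go, it remains open whether the three-membered ring itself or the extra carbon matters; isopropyl on the same nitrogen would separate the two.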